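Nitro in Place of Trifluoromethyl on the Smallest Macrocycle

The source may hold more compounds than are shown below. What is called first, only, known or untested is meant among the compounds shown, and "the series" means these compounds.

Compound 1 `FC(F)(F)c1ccc(COc2cccc(Nc3ncnc4cc5c(cc34)OCCOCCOCCO5)c2)cc1`: 34000 nM
Compound 2 `O=[N+]([O-])c1ccc(COc2cccc(Nc3ncnc4cc5c(cc34)OCCOCCOCCOCCO5)c2)cc1`: 9820 nM
Compound 3 `FC(F)(F)c1ccc(COc2cccc(Nc3ncnc4cc5c(cc34)OCCOCCO5)c2)cc1`: > 100000 nM

In a functional assay on HepG2 cells (Homo sapiens) for antiproliferative activity, read by MTT assay, with a stated time of 72 h (on this read-out higher numbers stand for weaker inhibition and lower numbers for stronger inhibition), compound 3 gives > 100000 nM, which is a limit of the assay and not a measured number. Compound 3 thus stands at the limit of > 100000 nM in this assay, at which 1 of the 3 values shown sits. Compound 1 and compound 2 each give a number, but both differ from compound 3 in more than one place, so no single step can be read from them. Compound 4 `O=[N+]([O-])c1ccc(COc2cccc(Nc3ncnc4cc5c(cc34)OCCOCCO5)c2)cc1` differs from compound 3 only by nitro in place of trifluoromethyl on an aromatic carbon. Because compound 3 sits at the limit of > 100000 nM in this assay, at which 1 of the 3 values shown sits, the step is expected to be a move from the limit down to a measurable number, estimated as an at least 2.5-fold lower number from compound 3 to compound 4 (0.39 log units; beyond the scatter). For compound 4 in this assay the expected value is 40000 nM, with a range from 10000 nM to 150000 nM.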

Compound 4, half-maximal inhibitory concentration: 65300 nM
For compound 4 the middle estimate is 1.6-fold (0.21 log units) below the measured one, and the stated range covers the measured number.
By their numbers in this assay, from the lowest: compound 2; then compounds 1 and 4 (each within the scatter of the next). At a limit, above all of these: compound 3.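

In this assay, going by these compounds alone, this is the first comparison in which only the group on this aromatic carbon changes, and it reads as an at least 1.5-fold lower number from compound 3 to compound 4 (0.18 log units; that floor lies within the scatter). Compound 3 gives > 100000 nM, which is a limit and not a number. On these data alone, compound 4 instead gives a measurable number, so nitro brings this core within the range of the assay, though the true size of the step remains unknown and may be small.

Within the data shown here, no steps involving compound 1 or compound 2 can be read, so the same change on their larger rings stays open. As far as these compounds go, how an amine or a nitrile at this position would compare also stays open.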